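The source may hold more compounds than are shown below. What is called first, only, known or untested is meant among the compounds shown, and "the series" means these compounds.

In a physicochemical assay for lipophilicity, measured as octanol-water partition (a higher number here means a more lipophilic compound, a lower number a more polar compound), compound 1 `C/C(=N\NC(=O)COc1cccc2ccccc12)c1ccc([N+](=O)[O-])cc1` gives 3.37 while compound 2 `COc1ccc(OC)c(/C=N/NC(=O)COc2cccc3ccccc23)c1` gives 3.51 and these two numbers lie within the usual scatter of each other. Among the measured compounds shown here, compound 1 therefore stands level with the only other measured compound, and nothing yet separates the two. Compound 3 `C/C(=N\NC(=O)COc1cccc2ccccc12)c1ccc(O)cc1` shares the core of compound 1 but for one change hydroxy in place of nitro on an aromatic carbon that puts hydroxy in place of nitro on an aromatic carbon. For the measured compounds named here, no pair of measured compounds shows this change or any other single change, so the judgement rests on the structures alone. A modest fall in this assay is expected here, and the estimated step of a number 0.37 log units lower from compound 1 to compound 3 (beyond the scatter) is not a large one. The expected value for compound 3 is 3 with an estimated range from 2.5 to 3.5 around it.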

Compound 3, partition coefficient: 4.44
For compound 3 the middle estimate is 1.44 log units below the measured one; the measured number lies above the stated range.
By their numbers in this assay, from the lowest: compounds 1 and 2 (each within the scatter of the next); then compound 3.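

In this assay, the group on this aromatic carbon, para to a large group, clearly counts: hydroxy in place of nitro gives a number 1.07 log units higher from compound 1 to compound 3 (beyond the scatter), with the rest of the core of compound 1 unchanged. Among the compounds shown here, compound 1 and compound 2 differ in more than one place and could not show this, so this is the only single change that can be read so far. Nothing measured here bears on the reason for the size or the direction of this step.

This one pair cannot tell whether the step belongs to the arrival of hydroxy or to the departure of nitro. From the compounds shown here alone, an amine, a carboxylic acid or a fluorine on this same carbon would help to separate the two, and it also remains open whether the same change would give a similar step on another core.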